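The source may report more compounds than this note shows. Statements on the series, on what has been measured and on what is new or still open speak of the compounds shown alone.

In a functional assay on the whole organism (Tail, strain ICR) with Mus musculus as the target, in the tail flick test, with a stated time of 90 min, at a dose of 25 umol/kg by the oral route (a lower number here means a weaker effect, a higher number a stronger effect of the compound at the dose given), compound 2 `CC(C)[C@H](NC(=O)CN(c1nc(Cl)nc2[nH]cnc12)C1CC1)C(=O)OCc1ccccc1` stands highest of the two measured compounds, giving 51.3%, while compound 1 `O=C(CN(c1nc(Cl)nc2[nH]cnc12)C1CC1)NCC(=O)OCc1ccccc1` gives 27.2%. For the measured compounds named here, the only measured step is a number 24.1 percentage points higher from compound 1 to compound 2 (beyond the scatter), in which isopropyl entered where compound 1 had hydrogen. Compound 3 `C[C@@H](O)[C@H](NC(=O)CN(c1nc(Cl)nc2[nH]cnc12)C1CC1)C(=O)OCc1ccccc1` differs from compound 2 by 1-hydroxyethyl in place of isopropyl on a saturated chain carbon bound to an amide-type nitrogen and a carbonyl carbon. Going by the values given here, no measured step exchanges isopropyl for 1-hydroxyethyl, so that single step bears on compound 3 only loosely; part of the gain seen in a number 24.1 percentage points higher from compound 1 to compound 2 (beyond the scatter) is expected to be given back. Compound 3 is therefore estimated at 40%, between 20% and 60%. That amounts to an expected step of a number 11.3 percentage points lower from compound 2 to compound 3 (beyond the scatter).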

Compound 3, a percentage reported as activity, at one dose (the size of the read-out at that dose, not a potency): 29.9%
Compound 3: the middle estimate sits 10.1 percentage points above what was measured, and the stated range covers the measured number.
By their numbers in this assay, from the lowest: compounds 1 and 3 (each within the scatter of the next); then compound 2.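

This position separates two groups of the same size by heavy-atom count: 1-hydroxyethyl, which carries an oxygen and a hydrogen-bond donor, in place of isopropyl gives a number 21.4 percentage points lower from compound 2 to compound 3 (beyond the scatter) in this assay. Set against hydrogen, 1-hydroxyethyl gives a number 2.7 percentage points higher from compound 1 to compound 3 (within the scatter), so the gain seen with isopropyl does not carry over to this group. Nothing available explains this difference.

From the compounds shown here alone, it remains open how a longer chain such as sec-butyl, a methyl ether of the hydroxyl group or a carboxylic acid at this place would compare with isopropyl.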